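Amide series: cytotoxicity notes toward compound 4

This account rests on a few compounds, and the source may have more. Where it says the series, first, only, none or still open, it means among the compounds named here.

Compound 1 `CC(Sc1nnc(-c2ccncc2)s1)C(=O)Nc1ccccc1` and compound 3 `O=C(CCSc1nnc(-c2ccncc2)s1)NCc1ccccc1Cl` share the core of compound 2 `CC(Sc1nnc(-c2ccncc2)s1)C(=O)NCc1ccc(Cl)cc1` and differ in the amide-bearing side chain and its substituent. In an ADME assay on HepG2 cells (Homo sapiens) for cytotoxicity, with a stated time of 3 days (on this read-out lower numbers stand for higher toxicity in this test and higher numbers for lower toxicity in this test), compound 1 gives > 50000 nM, a limit of the test and not a number. Compound 3 likewise gives > 50000 nM in this assay, again a limit. For compound 2 no value was obtained in this assay, where it is recorded as "not determined" (no result reported); compound 2 thus has no number of its own, and the other two results sit at the limit of > 50000 nM in this assay, at which 2 of the 3 values shown sit. Compound 4 `CC(Sc1nnc(-c2ccncc2)s1)C(=O)Nc1ccc(Cl)cc1` carries 4-chlorophenyl in place of 4-chlorobenzyl on an amide-type nitrogen. For the measured compounds named here, no measured step bears on this change, and no shift beyond the scatter is expected, so compound 4 is estimated at 50000 nM, range 20000 nM to 100000 nM, most likely reported as a limit.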

Compound 4, half-maximal cytotoxic concentration: > 50000 nM
Compound 4 ended at the assay's limit; the forecaster's own chance of this, stated with the estimate: 75%; the middle value sits exactly at the limit.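

For the compounds shown here, compound 1 and compound 4 both end at a limit of this assay, so no step between them can be read: the limit of > 50000 nM in this assay, at which 3 of the 4 values shown sit.
The compounds shown leave open whether chloro in place of hydrogen on an aromatic carbon changes the half-maximal cytotoxic concentration at all.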